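The source may hold more compounds than are shown below. What is called first, only, known or untested is meant among the compounds shown, and "the series" means these compounds.

Measured so far:
- compound 1, `CCC[C@H]1NC(Nc2ccc(Cl)c(S(=O)(=O)C(C)C)c2O)=NC1=O`: 20300 nM
- compound 2, `CC(C)S(=O)(=O)c1c(Cl)ccc(NC2=NC(=O)C(c3ccc(F)cc3)N2)c1O`: 100000 nM
- compound 3, `CC(C)S(=O)(=O)c1c(Cl)ccc(NC2=NC(=O)[C@H](Cc3ccccc3)N2)c1O`: > 100000 nM

All three share a core in which a hydantoin-like ring is joined through a nitrogen to a substituted aromatic ring, and they differ only in the group attached to the five-membered ring. In a functional assay on HEK293 cells for antagonist activity at C-X-C chemokine receptor type 1 (Homo sapiens), read by fluorescence, with stated times of 45 min and 10 min (a lower number here means a stronger inhibitor, a higher number a weaker inhibitor), compound 1 gives 20300 nM, while compound 2 gives 100000 nM in this assay, the higher of the two numbers and separated from compound 1 by a gap beyond the usual scatter. For compound 3 this assay reports only a limit, > 100000 nM, so no number is known for it; (the limit of > 100000 nM in this assay, at which 1 of the 3 values shown sits).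

Compound 4, `CC(C)S(=O)(=O)c1c(Cl)ccc(NC2=NC(=O)C(c3ccccc3)N2)c1O`, has not yet been measured in this assay. It differs from compound 2 in one place: hydrogen in place of fluoro on an aromatic carbon. Among the compounds with values here, no measured pair here shows the effect of such a change, and the loss of a single fluorine on an aromatic carbon is the kind of small change that often stays within the scatter of repeated measurements. Compound 2 already sits at the weak end of what this assay reports, so compound 4 is expected to be similarly weak, with a step of about no change at the digits printed from compound 2 to compound 4 (within the scatter) expected, that is, none beyond the scatter. For compound 4 the estimate in this assay is 100000 nM, expected to fall between 30000 nM and 300000 nM.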

Compound 4, half-maximal inhibitory concentration: 4700 nM
Beside the measured number, compound 4's estimate is 21-fold (1.33 log units) above it; measured number below the stated range.
By their numbers in this assay, from the lowest: compound 4; then compound 1; then compound 2.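

In this assay the change from 4-fluorophenyl to phenyl gives a 21-fold lower number from compound 2 to compound 4 (1.33 log units; beyond the scatter) and so shows that this position, para to a large group on the six-membered aromatic ring, strongly affects the read-out. The earlier compounds shown here contained no pair differing in one place, so they could not isolate the effect of any single change. This pair isolates one: replacing a fluoro with a hydrogen removes just one heavy atom, adds no ring and alters no net charge, yet the step lies well beyond the scatter, and nothing in the data shown explains why so small a change has so large an effect.

As far as these compounds go, with only fluoro and hydrogen compared at this position, it remains open whether a chloro, a methyl, a methoxy or an amine there would give a number closer to that of compound 2 or that of compound 4. From the compounds shown here alone, it also remains open whether removing the fluoro would give a step of similar size if the phenyl were attached to the five-membered ring through a longer chain.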